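One Phenyl Group Exchanged for Another

This account rests on a few compounds, and the source may have more. Where it says the series, first, only, none or still open, it means among the compounds named here.

In a functional assay on MCF7 cells (Homo sapiens) for cytotoxicity, read by MTT assay, with a stated time of 72 h (a lower number here means a stronger inhibitor, a higher number a weaker inhibitor), compound 1 `COc1ccc(OC)c(/C=C/C(=O)Nc2cc3c(Nc4ccc(F)c(Cl)c4)ncnc3cc2O[C@H]2CCOC2)c1` gives 36300 nM and compound 2 `O=C(/C=C/c1ccc(F)cc1Cl)Nc1cc2c(Nc3ccc(F)c(Cl)c3)ncnc2cc1O[C@H]1CCOC1` gives 26200 nM, so compound 2 stands level with compound 1 within the usual scatter of such measurements. Compound 3 `O=C(/C=C/c1ccc(Br)cc1)Nc1cc2c(Nc3ccc(F)c(Cl)c3)ncnc2cc1O[C@H]1CCOC1` has not yet been measured. It carries 4-bromophenyl in place of 2-chloro-4-fluorophenyl on a double-bonded chain carbon bound to a double-bonded chain carbon. Among the measured compounds shown here, only one measured step bears on this change, as it also exchanges the group at that place: a 1.4-fold lower number from compound 1 to compound 2 (0.14 log units; within the scatter), which stays within the scatter. With a single small step as a guide, no shift beyond the scatter is expected in this assay, and the expected step is a 1.1-fold higher number from compound 2 to compound 3 (0.03 log units; within the scatter). For compound 3 the estimated value is 28000 nM, with an expected range from 11000 nM to 70000 nM.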

Compound 3, half-maximal inhibitory concentration: 32400 nM
For compound 3 the middle estimate is 1.2-fold (0.06 log units) below the measured one; measured number inside the range.
By their numbers in this assay, from the lowest: compounds 2, 3 and 1 (each within the scatter of the next).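

In this assay, a third phenyl group on this double-bonded chain carbon again leaves the reading within the scatter, with a 1.2-fold higher number from compound 2 to compound 3 (0.09 log units; within the scatter) and a 1.1-fold lower number from compound 1 to compound 3 (0.05 log units; within the scatter). Among the compounds shown here, the earlier single step compared only two groups, whereas 2,5-dimethoxyphenyl, 2-chloro-4-fluorophenyl and 4-bromophenyl now all read alike here, even though 4-bromophenyl carries a single substituent on its ring. No measurement is available that would explain this flat result.

Going by these compounds, all three compounds carry a substituted phenyl ring at this place, so it remains open what a phenyl ring bearing an amine or a carboxylic acid would do, or a small group with no ring, such as methyl. On these data alone, whether any group here can move the number beyond the scatter in this assay also stays open.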